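This account rests on a few compounds, and the source may have more. Where it says the series, first, only, none or still open, it means among the compounds named here.

Measured so far in a physicochemical assay for solubility, read by LC-MS, in phosphate buffer, with a stated time of 24 h, at pH 7.4; on this read-out lower numbers stand for lower solubility and higher numbers for higher solubility:
- compound 1 `C[C@@H]1CC(=O)N(c2cnc(NCc3c(F)ccc4c3CCO4)n3cnnc23)C1`: 130000 nM
- compound 2 `CN(C(=O)c1ccccc1)c1cnc(NCc2c(F)ccc3c2CCO3)n2cnnc12`: 280000 nM
- compound 3 `O=C(Nc1cnc(NCc2c(F)ccc3c2CCO3)n2cnnc12)c1ccccc1`: 2000 nM

Compound 3 has the lowest number of the three, well apart from the other two. The next step leads to compound 4 `C[C@H]1CC(=O)N(c2cnc(NCc3c(F)ccc4c3CCO4)n3cnnc23)C1`, which has not yet been measured. In this step, 4-methyl-2-oxopyrrolidin-1-yl takes the place of benzamido on an aromatic carbon of the shared core: 4-methyl-2-oxopyrrolidin-1-yl in place of benzamido on an aromatic carbon.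

The closest evidence is compound 1, which carries the same 4-methyl-2-oxopyrrolidin-1-yl group at the same place, but with the opposite arrangement at its defined stereocentre. The measured step of a 65-fold lower number from compound 1 to compound 3 (1.81 log units; beyond the scatter) is the same exchange of groups run in the opposite direction, and it is large. Compound 2 adds context: a 140-fold lower number from compound 2 to compound 3 (2.15 log units; beyond the scatter) is also large, and it shows that removing a single methyl from the amide nitrogen accounts for a gap of similar size. a 2.2-fold higher number from compound 1 to compound 2 (0.33 log units; beyond the scatter) is modest by comparison.

Among the measured compounds shown here, no measured pair shows what reversing the stereocentre does on its own, so a number close to that of compound 1 is assumed, with a wide margin. A large rise is therefore expected in this assay, and the expected step is a 65-fold higher number from compound 3 to compound 4 (1.81 log units; beyond the scatter). The estimate for compound 4 is 130000 nM, with an expected range from 55000 nM to 300000 nM.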

Compound 4, solubility: 200000 nM
Beside the measured number, compound 4's estimate is 1.5-fold (0.19 log units) below it; low and high end bracket the measured number.
By their numbers in this assay, from the lowest: compound 3; then compounds 1, 4 and 2 (each within the scatter of the next, the first and the last beyond it).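

Among the compounds shown here, the pair of compounds 1 and 4 gives the first direct look at the stereocentre, and it shows a 1.5-fold higher number from compound 1 to compound 4 (0.19 log units; within the scatter), so in this assay reversing the drawn configuration of the 4-methyl-2-oxopyrrolidin-1-yl group produces no difference that this read-out can separate, and the comparison isolates that one feature: the fact that compounds 1 and 4 differ only in the configuration as drawn. The large gap to the benzamido compound therefore holds for both configurations of the ring, and the step for this exchange is a 100-fold higher number from compound 3 to compound 4 (2.00 log units; beyond the scatter). For the compounds shown here, the methylated amide and the ring also cannot be told apart at this position, as a 1.4-fold lower number from compound 2 to compound 4 (0.15 log units; within the scatter) shows, which leaves compound 3, the only one of the four compounds that keeps the amide hydrogen at this place, alone at the low end.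

Four compounds cannot show whether the amide hydrogen goes with a low number in general, and a small acetamido group or a plain amine on the same aromatic carbon would test that idea away from the benzene ring. As far as these compounds go, it also remains open whether the ring without its methyl, 2-oxopyrrolidin-1-yl, would read like compounds 1 and 4.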